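This account rests on a few compounds, and the source may have more. Where it says the series, first, only, none or still open, it means among the compounds named here.

Compound 1 `C=CCn1c(SCC(=O)Nc2ccc(C(C)=O)cc2)nnc1-c1ccccc1`: 54%
Compound 2 `C=CCn1c(SCC(=O)Nc2ccc(C(C)=O)cc2)nnc1-c1ccc(OC)c(OC)c1`: 58%
Compound 3 `C=CCn1c(SCC(=O)Nc2ccc(/C(C)=N/O)cc2)nnc1-c1ccc(OC)cc1`: 63%

In a functional assay on the whole organism (strain albino) for inhibition, with Rattus norvegicus as the target, read by paw edema, with stated times of 30 min and 3 h, at a dose of 0.28 mmol/kg by the oral route (a higher number here means more inhibition at the dose given (going by the name of the read-out), a lower number less inhibition), compound 3 gives the highest of the three numbers shown, though compound 2 and compound 1 both lie within the scatter of it. Compound 4 `C=CCn1c(SCC(=O)Nc2ccc(C(C)=O)cc2)nnc1-c1ccc(OC)cc1` is compound 3 with one change: a group of 3 heavy atoms (2 carbon, 1 oxygen; no ring) in place of a group of 4 heavy atoms (2 carbon, 1 nitrogen, 1 oxygen; no ring), on an aromatic carbon. For the measured compounds named here, no measured step touches this change; the only measured step, a number 4 percentage points higher from compound 1 to compound 2 (within the scatter), alters the other ring and stays within the scatter. Compounds 1 and 2 already carry acetyl at this place, and their values sit close to that of compound 3, so the change is expected to move the number little, if at all. Compound 4 is therefore estimated at 58%, between 46% and 70%. The expected step is a number 5 percentage points lower from compound 3 to compound 4 (within the scatter).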

Compound 4, a percentage reported as inhibition, in the whole organism at one dose (the size of the read-out at that dose, not a potency): 52%
Estimate against measurement, compound 4: 6 percentage points above; low and high end bracket the measured number.
By their numbers in this assay, from the lowest: compounds 4, 1, 2 and 3 (each within the scatter of the next, the first and the last beyond it).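

In this assay, for the compounds shown here, acetyl in place of the group of 4 heavy atoms on the aromatic carbon para to a large group gives the first step beyond the scatter: a number 11 percentage points lower from compound 3 to compound 4 (beyond the scatter). On the other ring, the methoxy changes stay within the scatter, with a number 6 percentage points lower from compound 2 to compound 4 (within the scatter) and a number 2 percentage points lower from compound 1 to compound 4 (within the scatter). No measurement shown here explains the step at this position.

On these data alone, whether an amine or a carboxylic acid at this place would give a number like that of compound 3 remains open. Also open, as far as these compounds go, is whether the same step appears with a different group on the other ring.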